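The compounds below may be only part of what the source reports. "The series", "measured", "known", "first", "only" and "open" are said of these compounds alone.

Measured compounds in the series:

Compound 1 `O=C1NCCN1c1ccc(S(=O)(=O)Nc2ccc3[nH]ccc3c2)cc1`: 130 nM
Compound 2 `Cc1ccc(NS(=O)(=O)c2ccc(N3CCNC3=O)cc2)cc1C`: 230 nM
Compound 3 `CCCCOc1ccc(NS(=O)(=O)c2ccc(N3CCNC3=O)cc2)cc1`: 630 nM

All three were read in a functional assay on HT-29 cells (Homo sapiens) for antiproliferative activity, read by sulforhodamine B assay, with a stated time of 48 h; on this read-out lower numbers stand for stronger inhibition and higher numbers for weaker inhibition. Among the three numbers compound 2 stands second highest. Its nearest neighbour is compound 1, whose value lies within the usual scatter of compound 2, so no order between the two can be claimed. Its furthest neighbour is compound 3, whose higher number lies beyond the scatter and so marks a real, weaker result for compound 3.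

Compound 4 `COc1ccccc1NS(=O)(=O)c1ccc(N2CCNC2=O)cc1` has not yet been measured in this assay. Relative to compound 2 the change is 2-methoxyphenyl in place of 3,4-dimethylphenyl on a sulfonamide nitrogen. For the measured compounds named here, no step between two measured compounds that differ in one place is available, so the size of this change cannot be calibrated directly from the series. The three measured values span a modest range, and the substituent swap keeps the same ring count and size, so the expected step in this assay is small, most likely toward a higher number, or none beyond the scatter.

Compound 4 is therefore expected to give 350 nM, with a range from 150 nM to 900 nM. That estimate corresponds to an expected step of a 1.5-fold higher number from compound 2 to compound 4 (0.18 log units; within the scatter).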

Compound 4, half-maximal inhibitory concentration: 550 nM
The estimate for compound 4 lay 1.6-fold (0.20 log units) below the measured number; the range from low to high includes it.
By their numbers in this assay, from the lowest: compounds 1 and 2 (each within the scatter of the next); then compounds 4 and 3 (each within the scatter of the next).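

Working notes on the sulfonamide nitrogen: in this assay the exchange of 3,4-dimethylphenyl for 2-methoxyphenyl gives the first step that can be read in the series, a 2.4-fold higher number from compound 2 to compound 4 (0.38 log units; beyond the scatter). This position is therefore sensitive to the choice of aryl group, even though the leaving and entering groups have the same heavy-atom count and each holds one six-membered aromatic ring of carbon only, so matching ring and size does not by itself preserve the number. The entering group replaces one carbon with oxygen and brings a hydrogen-bond acceptor, but no measurement here bears on what lies behind the step.

For the compounds shown here, with only this pair, the step cannot be divided between the loss of the two methyl groups and the arrival of the methoxy group, and a single exchange gives no trend for this position. Also open, as far as these compounds go, is how the number would respond to a phenyl ring on the same nitrogen carrying an amine or a carboxylic acid, which would test whether the step extends beyond these two aryl groups.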